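Pyridin-3-yl to pyridin-4-yl in the series

The source may hold more compounds than are shown below. What is called first, only, known or untested is meant among the compounds shown, and "the series" means these compounds.

In a functional assay on MCF7 cells (Homo sapiens) for inhibition, read by CCK-8 assay, with a stated time of 72 h (a lower number here means a stronger inhibitor of growth, a higher number a weaker inhibitor of growth), compound 1 (`C#Cc1cccc(Nc2ncnc3cc(OC)c(OCCCCCCN/C(=N\C#N)Nc4cccnc4)cc23)c1`) gives 24.6 nM as its measured value. Compound 2 (`C#Cc1cccc(Nc2ncnc3cc(OC)c(OCCCCCCCN/C(=N\C#N)Nc4cccnc4)cc23)c1`) gives 42.1 nM in the same read-out, and compound 3 (`C#Cc1cccc(Nc2ncnc3cc(OC)c(OCCCCCN/C(=N\C#N)Nc4ccncc4)cc23)c1`) gives 38 nM there. All three numbers lie within the usual scatter of one another, so compound 1 stands level with the other two.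

Compound 4 (`C#Cc1cccc(Nc2ncnc3cc(OC)c(OCCCCCCN/C(=N\C#N)Nc4ccncc4)cc23)c1`) has not yet been measured. It departs from compound 1 by a single exchange: pyridin-4-yl in place of pyridin-3-yl on an amine nitrogen with pyridin-4-yl in place of pyridin-3-yl on an amine nitrogen.

For the measured compounds named here, no two measured compounds differ in one place only, so the size of this exchange has not been seen directly in this assay at this point. The closest evidence is indirect. Compound 3 also carries pyridin-4-yl on an amine nitrogen, though on a different chain from compound 4. Compound 3 reads 38 nM and compound 1 reads 24.6 nM within the scatter of each other.

No step beyond the scatter is therefore expected, in either direction. The estimated 1.2-fold higher number from compound 1 to compound 4 (0.09 log units; within the scatter) is expected to stay inside that scatter. For compound 4 the expected value is 30 nM with an estimated range from 14 nM to 65 nM in this assay once it is measured.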

Compound 4, concentration for 50% growth inhibition: 7.47 nM
Estimate against measurement, compound 4: 4.0-fold (0.60 log units) above, outside the stated range (below it).
By their numbers in this assay, from the lowest: compound 4; then compounds 1, 3 and 2 (each within the scatter of the next).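

In this assay the exchange of pyridin-3-yl for pyridin-4-yl on the amine nitrogen can now be read directly, as a 3.3-fold lower number from compound 1 to compound 4 (0.52 log units; beyond the scatter), and this step lies beyond the scatter. The earlier compounds shown here stood within the scatter of one another and gave no such separation, whereas this pair shows that the response at this position depends on how the pyridine ring is attached, even though the group that leaves and the group that enters have the same atoms and the same counts of donors and acceptors. Nothing available bears on why pyridin-4-yl gives the lower number here, so the step stands as an observation only.

On these data alone, it remains open whether the same exchange keeps its size on a shorter or longer chain, since this single pair shows it on one chain only. Also open, as far as these compounds go, is where pyridin-2-yl, a plain phenyl ring or a pyrimidine ring on the same amine nitrogen would fall relative to the two pyridine groups read so far.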